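Allyl in place of methoxyethyl at the chain carbon

A few compounds are considered here, and "the series" means these few. Any claim that something is new, unique, unknown or untested is made for them only; others in the source may bear on it.

The shared core is seen in compound 1 `C[C@H](C(=O)Nc1nccs1)c1ccc(Cl)cc1`, which in a functional assay on CHO cells for agonist activity at Free fatty acid receptor 2 (Homo sapiens), read by cAMP accumulation (on this read-out higher numbers stand for larger maximal responses and lower numbers for smaller maximal responses), gives 83%. Compound 2 `CCC[C@H](C(=O)Nc1nccs1)c1ccc(Cl)cc1` gives 108% in this assay, and compound 3 `COCC[C@H](C(=O)Nc1nccs1)c1ccc(Cl)cc1` gives 53% in this assay, the lowest of the three numbers. The steps were a number 25 percentage points higher from compound 1 to compound 2 (beyond the scatter), a number 30 percentage points lower from compound 1 to compound 3 (beyond the scatter) and a number 55 percentage points lower from compound 2 to compound 3 (beyond the scatter). Compound 4 `C=CC[C@H](C(=O)Nc1nccs1)c1ccc(Cl)cc1` differs from compound 3 by vinyl in place of methoxymethyl on a saturated chain carbon, two bonds along the chain from an aromatic carbon and a carbonyl carbon. The step bearing on it most is a number 55 percentage points lower from compound 2 to compound 3 (beyond the scatter), where the oxygen was brought in; compound 4 removes it again. Compound 4 is therefore expected to rise in this assay by a number 42 percentage points higher from compound 3 to compound 4 (beyond the scatter), toward compound 2, and its efficacy is estimated at 95%, in the range from 70% to 115%.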

Compound 4, largest response reached (reported as efficacy), in percent of the reference or control that the assay uses: 88%
For compound 4 the middle estimate is 7 percentage points above the measured one; low and high end bracket the measured number.
By their numbers in this assay, from the lowest: compound 3; then compounds 1 and 4 (each within the scatter of the next); then compound 2.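

Going from 2-methoxyethyl to allyl gives a number 35 percentage points higher from compound 3 to compound 4 (beyond the scatter) in this assay, so the low response of compound 3 does not extend to this chain without the oxygen. Allyl does not match the saturated chain, with a number 20 percentage points lower from compound 2 to compound 4 (beyond the scatter), while a number 5 percentage points higher from compound 1 to compound 4 (within the scatter) shows no separation from the shorter chain. Nothing available explains these differences.

On these data alone, whether an amine or a carboxylic acid at this chain carbon would track compound 3 or compound 2 remains open, as does the response to a longer chain.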